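Removing the trifluoromethyl from the benzoyl amide

A few compounds are considered here, and "the series" means these few. Any claim that something is new, unique, unknown or untested is made for them only; others in the source may bear on it.

Compound 1 `COc1cc(-c2nn(-c3cccc(NC(=O)Nc4cc(C(F)(F)F)cc(C(F)(F)F)c4)c3)cc2-c2ccncc2)ccc1Cl`: 10100 nM
Compound 2 `COc1cc(-c2nn(-c3cccc(NC(=O)c4cccc(C(F)(F)F)c4)c3)cc2-c2ccncc2)ccc1Cl`: > 50000 nM
Compound 3 `O=C(Nc1cccc(-n2cc(-c3ccncc3)c(-c3ccc(Cl)c(O)c3)n2)c1)Nc1cc(C(F)(F)F)cc(C(F)(F)F)c1`: 14200 nM

In a functional assay on TK-10 cells (Homo sapiens) for inhibition, read by sulforhodamine B assay, with a stated time of 48 h (on this read-out higher numbers stand for lower toxicity in this test and lower numbers for higher toxicity in this test), compound 1 gives 10100 nM. Compound 3, which carries hydrogen in place of methyl on an oxygen on an aromatic ring, gives 14200 nM; the step of a 1.4-fold higher number from compound 1 to compound 3 (0.15 log units; within the scatter) is within the scatter. Compound 2 is known only as a limit of this assay, > 50000 nM, so where it truly stands is not known. This is the line at which one of the three values sits (the limit of > 50000 nM in this assay, at which 1 of the 3 values shown sits).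

Compound 4 `COc1cc(-c2nn(-c3cccc(NC(=O)c4ccccc4)c3)cc2-c2ccncc2)ccc1Cl` differs from compound 2 by a single change, (hydrogen in place of trifluoromethyl on an aromatic carbon). Within the data shown here, no measured step here alters the amide part of the molecule, so the only step known, from methyl to hydrogen on the oxygen, tells nothing about this change. With compound 2 already at the limit, compound 4 is expected to stay near it as well; the step of a number no higher from compound 2 to compound 4 (the limit leaves the size open) is estimated to be small. The estimate for compound 4 in this assay is 50000 nM, within 20000 nM to 150000 nM.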

Compound 4, concentration lethal to 50% of the cells: > 100000 nM
Compound 4 gave a limit, no number; the forecaster's own chance of this, stated with the estimate: 70%; middle value at least 2.0-fold (0.30 log units) from the limit.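

Compound 2 and compound 4 are both known only as limits in this assay, and no step can be read between them. The compounds shown leave open how much hydrogen in place of trifluoromethyl on the aromatic carbon changes the value, or whether it changes it at all.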